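The source may report more compounds than this note shows. Statements on the series, on what has been measured and on what is new or still open speak of the compounds shown alone.

Compound 1 `O=C(/C=C/C1=Cc2ccccc2OC1)c1ccccc1F`: 64.4%
Compound 2 `O=C(/C=C/C1=Cc2ccccc2OC1)c1cccc(F)c1`: 52.4%
Compound 3 `O=C(/C=C/C1=Cc2ccccc2OC1)c1ccccc1Cl`: 52.3%

In a functional assay on the whole organism for inhibition, with Mus musculus as the target, with a stated time of 1 h, at a dose of 30 mg/kg by the intraperitoneal route (on this read-out lower numbers stand for less inhibition and higher numbers for more inhibition at the one dose given (going by the name of the read-out)), compound 1 gives 64.4%, compound 2 gives 52.4% and compound 3 gives 52.3%. Compound 3 stands lowest of the three numbers, though its separation from compound 2 is only a number 0.1 percentage points lower from compound 2 to compound 3 (within the scatter) and lies within the scatter, so the two cannot be ordered; its separation from compound 1 is a number 12.1 percentage points lower from compound 1 to compound 3 (beyond the scatter) and lies beyond it.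

Compound 4 `O=C(/C=C/C1=Cc2ccccc2OC1)c1cccc(Cl)c1` differs from compound 3 in one place: 3-chlorophenyl in place of 2-chlorophenyl on a carbonyl carbon. Among the compounds with values here, the one measured step that bears on this is the one in which the fluoro compound underwent the same shift of the halogen, from compound 1 to compound 2, which gave a number 12 percentage points lower from compound 1 to compound 2 (beyond the scatter). The step from compound 2 to compound 3, a number 0.1 percentage points lower from compound 2 to compound 3 (within the scatter), shows that exchanging one halogen for the other while changing its position left the number where it was, so it sets no limit on the present change. A downward step of similar size in this assay is therefore expected for compound 4, although the fluoro pair alone supports it and the lower end is uncertain.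

Compound 4 is therefore estimated to give 42%, between 28% and 58%, an expected step of a number 10.3 percentage points lower from compound 3 to compound 4 (beyond the scatter).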

Compound 4, a percentage reported as inhibition, in the whole organism at one dose (the size of the read-out at that dose, not a potency): 51%
The estimate for compound 4 lay 9 percentage points below the measured number; measured number inside the range.
By their numbers in this assay, from the lowest: compounds 4, 3 and 2 (each within the scatter of the next); then compound 1.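

In this assay, 3-chlorophenyl in place of 2-chlorophenyl on the carbonyl carbon gave a number 1.3 percentage points lower from compound 3 to compound 4 (within the scatter), so the step seen in the fluoro pair did not recur in the chloro pair. The 2-fluorophenyl group alone now stands apart, at a number 13.4 percentage points lower from compound 1 to compound 4 (beyond the scatter), while chloro in place of fluoro on the 3-halophenyl pair gave a number 1.4 percentage points lower from compound 2 to compound 4 (within the scatter). The halogen exchange looks different in the two pairs, yet that difference cannot be claimed as real: the same change on two cores in this assay, a number 12.1 percentage points lower (beyond the scatter) from compound 1 to compound 3 and a number 1.4 percentage points lower (within the scatter) from compound 2 to compound 4, 10.7 percentage points apart, within the scatter of two such steps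

The compounds shown leave open how an unsubstituted phenyl, a methoxy group or an amine on this ring would compare with the 2-fluorophenyl group. They also leave open whether the separation of compound 1 from the others would hold at other doses.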